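Replacing fluoro with methoxy in compound 1

The compounds below may be only part of what the source reports. "The series", "measured", "known", "first", "only" and "open" are said of these compounds alone.

- compound 1 `COc1cc(-c2ncnn2-c2ccc(F)cc2)cc(OC)c1OC` gives > 10000 nM (a limit)
- compound 2 `CCOc1cccc(-c2ncnn2-c2cc(OC)c(OC)c(OC)c2)c1` gives > 10000 nM (a limit)
- compound 3 `CCOc1ccc(-c2ncnn2-c2cc(OC)c(OC)c(OC)c2)cc1` gives 20 nM (a number)

In a functional assay on HL-60 cells (Homo sapiens) for antiproliferative activity, read by MTT assay, with a stated time of 72 h (on this read-out lower numbers stand for stronger inhibition and higher numbers for weaker inhibition), compound 1 gives > 10000 nM as a limit and not a number, so it stands at the limit of > 10000 nM in this assay, at which 2 of the 3 values shown sit, without a measured potency. Compound 4 `COc1ccc(-n2ncnc2-c2cc(OC)c(OC)c(OC)c2)cc1` keeps the core of compound 1 and differs by methoxy in place of fluoro on an aromatic carbon. Among the measured compounds shown here, compound 3 bears an alkoxy group and gives 20 nM as the only number. Compound 2 also bears one and gives > 10000 nM as a limit, so support is loose. A large move towards stronger inhibition is expected, estimated as an at least 66-fold lower number from compound 1 to compound 4 (1.82 log units; beyond the scatter) with wide uncertainty. Compound 4 is expected near 150 nM within an estimated range of 15 nM to 3000 nM in this assay here.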

Compound 4, half-maximal inhibitory concentration: 6200 nM
Beside the measured number, compound 4's estimate is 41-fold (1.62 log units) below it; the whole stated range lies below it.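

In this assay, going from 4-fluorophenyl to 4-methoxyphenyl on an aromatic carbon para to a large group replaces a limit with a measured number. The change reads as an at least 1.6-fold lower number from compound 1 to compound 4 (0.20 log units; that floor lies within the scatter) and so establishes no gain beyond the scatter, though a larger one remains possible. Compound 1 stays a limit, which leaves the true size of the step unfixed: (the limit of > 10000 nM in this assay, at which 2 of the 4 values shown sit).

Going by these compounds, what an amine or a carboxylic acid would give at this position stays open. So does the effect of a chloro or hydroxy group there.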